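This account rests on a few compounds, and the source may have more. Where it says the series, first, only, none or still open, it means among the compounds named here.

Measured compounds in a functional assay on MDA-MB-231 cells (Homo sapiens) for inhibition, read by sulforhodamine B assay, with a stated time of 48 h; on this read-out higher numbers stand for weaker inhibition of growth and lower numbers for stronger inhibition of growth:
- compound 1 `Nc1cc(N)c2nc(-c3ccccc3)c(NCc3ccc(Cl)c(Cl)c3)nc2c1` gives 1580 nM
- compound 2 `Nc1cc(N)c2nc(-c3ccccc3)c(NCc3ccc(F)cc3)nc2c1` gives 2140 nM
- compound 3 `Nc1cc(N)c2nc(-c3ccccc3)c(Sc3ccc(Cl)c(Cl)c3)nc2c1` gives 16600 nM

Compound 3 carries the highest number of the three; the nearest is compound 2, and the gap a 7.8-fold higher number from compound 2 to compound 3 (0.89 log units; beyond the scatter) lies beyond the scatter, while compound 1 lies further away still. Compound 4 `Nc1cc(N)c2nc(-c3ccccc3)c(Sc3ccc(F)cc3)nc2c1` is not yet measured. It differs from compound 3 in one place: 4-fluorophenyl in place of 3,4-dichlorophenyl on a sulfur. Within the data shown here, the only measured step that bears on this change is the one between the two benzylamine compounds, where the same swap of aryl group gave a 1.4-fold higher number from compound 1 to compound 2 (0.13 log units; within the scatter), a step that stays within the scatter. Among the measured compounds shown here, the sulfanyl pair has no measured counterpart, so the expectation rests on that single step alone. Compound 4 is therefore expected to sit close to compound 3, with at most a small rise in the number, which is the step of a 1.2-fold higher number from compound 3 to compound 4 (0.08 log units; within the scatter) the estimate means. The estimated value for compound 4 in this assay is 20000 nM, with a range from 8000 nM to 50000 nM.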

Compound 4, concentration for 50% growth inhibition: 17400 nM
For compound 4 the middle estimate is 1.1-fold (0.06 log units) above the measured one; the measured number falls inside the stated range.
By their numbers in this assay, from the lowest: compounds 1 and 2 (each within the scatter of the next); then compounds 3 and 4 (each within the scatter of the next).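

In this assay, the step of a 1.0-fold higher number from compound 3 to compound 4 (0.02 log units; within the scatter) shows that exchanging 3,4-dichlorophenyl for 4-fluorophenyl on the sulfur leaves the number within the scatter, as the same exchange did among the benzylamines, so these two aryl groups are not told apart on either linker. Among these compounds, the step of an 8.1-fold higher number from compound 2 to compound 4 (0.91 log units; beyond the scatter) keeps the fluorine-bearing aryl group in both compounds and isolates the change of linker, and it shows a gap beyond the scatter, of much the same size as the one seen from compound 2 to compound 3. Nothing shown explains why the sulfanyl compounds give the higher numbers.

The compounds shown leave open whether that gap follows the sulfur or the missing chain carbon, which a (4-fluorobenzyl)sulfanyl or a (4-fluorophenyl)amino group would separate. They also leave open whether an aryl group carrying an amine or a carboxylic acid would stand apart from these two on either linker.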